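The source may hold more compounds than are shown below. What is called first, only, known or untested is meant among the compounds shown, and "the series" means these compounds.

Series around one shared core: compound 1 `c1ccc(-c2n[nH]cc2N2CCNCC2)cc1`, compound 2 `Clc1ccc(-c2n[nH]cc2N2CCNCC2)cc1`, compound 3 `Fc1ccc(-c2n[nH]cc2N2CCNCC2)cc1` and the as yet unmeasured compound 4 `Cc1ccc(-c2n[nH]cc2N2CCNCC2)cc1`. In an assay on isolated protein for binding affinity to 5-hydroxytryptamine receptor 1E (Homo sapiens) (on this read-out lower numbers stand for stronger inhibition and higher numbers for weaker inhibition), compound 1 reaches only the assay limit, > 10000 nM. Compound 2 likewise gives only a limit in this assay, > 10000 nM. Compound 3 too gives only a limit in this assay, > 10000 nM. Compound 3 therefore stands where every value shown stands, at the limit of > 10000 nM in this assay, at which 3 of the 3 values shown sit, with no number of its own. The steps a step that the two limits leave unreadable from compound 1 to compound 2, a step that the two limits leave unreadable from compound 1 to compound 3 and a step that the two limits leave unreadable from compound 2 to compound 3 all remain unreadable for this reason, so none of the three measured steps tells how a change on this aromatic carbon moves the read-out.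

Compound 4 differs from compound 3 by methyl in place of fluoro on an aromatic carbon. Going by the values given here, no measured step bears readably on this change; the only guidance is that every substitution on this carbon so far has left the compound at the limit. Compound 4 is therefore expected to give 15000 nM, with a range from 3000 nM to 80000 nM, most likely again only as a limit. The expected step that the limit leaves unreadable from compound 3 to compound 4 is accordingly estimated as nothing beyond the scatter.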

Compound 4, inhibition constant: > 10000 nM
Compound 4: only a limit was reported; the forecaster's own chance of this, stated with the estimate: 80%; the middle value does not contradict the limit.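

No new step can be read between compound 4 and compound 1, compound 2 or compound 3, since all four give only a limit: the limit of > 10000 nM in this assay, at which 4 of the 4 values shown sit.
The compounds shown leave open whether any group on this aromatic carbon gives a value inside the range of this assay.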